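Methyl for trifluoromethyl on a shared core

The compounds below may be only part of what the source reports. "The series", "measured", "known", "first", "only" and "open" are said of these compounds alone.

Measured compounds:
compound 1 `CC1(C)CN(C2=CCCC2=O)c2cc(N)ccc2S1` — "not determined" (no result reported)
compound 2 `CC(=O)Nc1ccc2c(c1)N(C1=CCCC1=O)CC(C)(C)S2` — "not determined" (no result reported)
compound 3 `CC1(C)CN(C2=CCCC2=O)c2cc(C(F)(F)F)ccc2S1` — 96%

Three compounds on a shared core have been examined in a functional assay on aorta (Rattus norvegicus, strain Wistar), in the presence of a further agent that is not named here; on this read-out lower numbers stand for smaller maximal responses and higher numbers for larger maximal responses. In this assay compound 1 stands as "not determined" (no result reported), and compound 2 stands as "not determined" (no result reported), so no number stands beside either of them. For the measured compounds named here, compound 3 is therefore the only compound with a number in this assay, and in this assay compound 3 gives 96%, a response close to that of the reference.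

Compound 4 `Cc1ccc2c(c1)N(C1=CCCC1=O)CC(C)(C)S2` has not yet been measured in this assay. It differs from compound 3 in one place: methyl in place of trifluoromethyl on an aromatic carbon. Going by the values given here, no step between two measured compounds is available to show how this assay answers such a change, so the expectation for compound 4 rests on compound 3 alone and on the small size of the change. Compound 4 is expected to stay within the usual scatter of compound 3, with the step of a number 6 percentage points lower from compound 3 to compound 4 (within the scatter) amounting to little more than noise, perhaps a slight drop.

In this assay compound 4 is estimated to give 90%, in a range from 72% to 104%.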

Compound 4, largest response reached (Emax), in percent of the reference or control that the assay uses: 78%
Compound 4: middle estimate off by 12 percentage points, on the high side; the range from low to high includes it.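

For the compounds shown here, the aromatic carbon that carries trifluoromethyl in compound 3 now proves sensitive to the group placed on it in this assay: exchanging it for methyl gives a number 18 percentage points lower from compound 3 to compound 4 (beyond the scatter), the first step at this position that can be read. The step is modest, and compound 4 still reaches 78%, so the response is reduced but far from lost. Nothing available here accounts for the drop.

Steps involving compound 1 or compound 2 cannot be read, so two groups alone offer numbers at this carbon and no trend can be drawn from them. Going by these compounds, how a nitrile, a chlorine atom or a methoxy group on the same aromatic carbon would place the maximal response remains open.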